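Adding a basic side chain to the trifluoromethyl anilide

The compounds below may be only part of what the source reports. "The series", "measured", "known", "first", "only" and "open" are said of these compounds alone.

The series shares one core, to which an anilide bearing a single substituent is attached. Compound 1 `COc1cccc(NC(=O)CCSc2ccc3c(/C=C/c4ccccn4)n[nH]c3c2)c1` carries a methoxy group and, in an ADME assay on BaF3 cells (Mus musculus) for antiproliferative activity, read by CCK-8 assay, with a stated time of 72 h (on this read-out lower numbers stand for stronger inhibition of growth and higher numbers for weaker inhibition of growth), compound 1 gives 3840 nM. Compound 2 `O=C(CCSc1ccc2c(/C=C/c3ccccn3)n[nH]c2c1)Nc1cccc(C(F)(F)F)c1` carries a trifluoromethyl group instead and in this assay compound 2 gives 2300 nM; the step is a 1.7-fold lower number from compound 1 to compound 2 (0.22 log units; within the scatter). Compound 3 `CN(C)c1cccc(NC(=O)CCSc2ccc3c(/C=C/c4ccccn4)n[nH]c3c2)c1` carries a dimethylamino group, and for compound 3 this assay reports only a limit, > 10000 nM. From compound 1 this is an at least 2.6-fold higher number from compound 1 to compound 3 (0.41 log units; beyond the scatter), and from compound 2 it is an at least 4.3-fold higher number from compound 2 to compound 3 (0.63 log units; beyond the scatter). Among the two numbers shown compound 2 holds the lowest one, with compound 1 as its nearest neighbour within the scatter.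

Compound 4 `CN(C)CCN(C)Cc1ccc(NC(=O)CCSc2ccc3c(/C=C/c4ccccn4)n[nH]c3c2)cc1C(F)(F)F` keeps the trifluoromethyl group of compound 2 and differs by ((2-(dimethylamino)ethyl)(methyl)amino)methyl in place of hydrogen on an aromatic carbon. None of the three measured steps adds a group at this position; they exchange the one substituent already present, so they bear on this step only loosely. For the measured compounds named here, the only weakening step seen, from compound 2 to compound 3, brought in a dimethylamino group, and the incoming chain here also contains one, so a modest rise is expected, a 1.5-fold higher number from compound 2 to compound 4 (0.18 log units; within the scatter). Compound 4 is therefore estimated at 3500 nM, within 900 nM to 10000 nM.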

Compound 4, concentration for 50% growth inhibition: 1850 nM
Beside the measured number, compound 4's estimate is 1.9-fold (0.28 log units) above it; the range from low to high includes it.
By their numbers in this assay, from the lowest: compounds 4, 2 and 1 (each within the scatter of the next, the first and the last beyond it). At a limit, above all of these: compound 3.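

In this assay, placing ((2-(dimethylamino)ethyl)(methyl)amino)methyl in place of hydrogen on this aromatic carbon, ortho to a trifluoromethyl group and para to a large group, gives a 1.2-fold lower number from compound 2 to compound 4 (0.09 log units; within the scatter). For the compounds shown here, this is the first view of a position that the earlier steps left untouched, and the read-out does not separate the compound with the added chain from the one without it. The earlier exchange of trifluoromethyl for dimethylamino gave an at least 4.3-fold higher number from compound 2 to compound 3 (0.63 log units; beyond the scatter), yet this chain, which also contains a dimethylamino group, shows no such rise, and compound 4 has a measured number whereas compound 3 stays at a limit: the limit of > 10000 nM in this assay, at which 1 of the 4 values shown sits.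

The compounds shown leave open whether the same flat result would hold for a shorter amine chain, a cyclic amine or a carboxylic acid at this position, since a single chain cannot show how much the position accepts. They also leave open whether this chain would behave alike without the trifluoromethyl group, for instance with methoxy in its place as in compound 1.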